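The compounds below may be only part of what the source reports. "The series", "measured", "known", "first", "only" and "open" are said of these compounds alone.

The study centres on compound 1 `CC(=O)Oc1cccc(N2C(=O)/C(=C/N3N=C(c4ccccc4)CC3c3ccc(N(C)C)cc3)SC2=S)c1`, which in a functional assay on HL-60 cells (Homo sapiens) for antiproliferative activity, read by MTT assay, with a stated time of 72 h (on this read-out higher numbers stand for weaker inhibition and lower numbers for stronger inhibition), gives 100 nM. Compound 2 `CN(C)c1ccc(C2CC(c3ccccc3)=NN2/C=C2\SC(=S)NC2=O)cc1` keeps the rest of the molecule but carries a hydrogen in place of the 3-acetoxyphenyl group; the change is hydrogen in place of 3-acetoxyphenyl on an amide-type nitrogen in a ring. For compound 2 this assay reports only a limit, > 10000 nM, so no number is known for it; such a limit is recorded as the limit of > 10000 nM in this assay, at which 1 of the 3 values shown sits. The step is therefore at least an at least 100-fold higher number from compound 1 to compound 2 (2.00 log units; beyond the scatter), a loss of activity well beyond the ordinary scatter.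

Compound 3 `CC(=O)Oc1cccc(N2C(=O)/C(=C/N3N=C(c4ccc5ccccc5c4)CC3c3ccc(Cl)cc3)SC2=S)c1` belongs to a different core; how its core differs from that of compound 1 is not broken down here. In this assay compound 3 gives 1020 nM, the highest of the two numbers recorded, and its distance from compound 1 lies beyond the ordinary scatter.

Compound 4 `O=C1NC(=S)S/C1=C\N1N=C(c2ccc3ccccc3c2)CC1c1ccc(Cl)cc1` has not been measured. It relates to compound 3 as compound 2 relates to compound 1: the change is hydrogen in place of 3-acetoxyphenyl on an amide-type nitrogen in a ring, and as the place of the change is described in the same words for both pairs, it is the same change made on a different core. Among the compounds with values here, since the only precedent, the step from compound 1 to compound 2, was an at least 100-fold higher number from compound 1 to compound 2 (2.00 log units; beyond the scatter), compound 4 is expected to lose activity by a comparable amount, an estimated 29-fold higher number from compound 3 to compound 4 (1.47 log units; beyond the scatter). Starting from the higher number of compound 3, compound 4 is therefore estimated at 30000 nM, with a plausible range from 5000 nM to 200000 nM, and it is quite likely that this assay will report only a limit for compound 4.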

Compound 4, half-maximal inhibitory concentration: 400 nM
Beside the measured number, compound 4's estimate is 75-fold (1.88 log units) above it; measured number below the stated range.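

In this assay, putting hydrogen in place of the 3-acetoxyphenyl group on the second core gives a 2.6-fold lower number from compound 3 to compound 4 (0.41 log units; beyond the scatter), a step opposite in direction to the large loss seen on the core of compound 1. The effect of this change therefore does not carry from one core to the other in this series, and the earlier step could not have served as a guide to this one: the same change on two cores in this assay, an at least 100-fold higher number (2.00 log units; beyond the scatter) from compound 1 to compound 2 and a 2.6-fold lower number (0.41 log units; beyond the scatter) from compound 3 to compound 4, at least 250-fold (2.40 log units) apart, beyond the scatter of two such steps This does not show which difference between the two cores decides the outcome, or how large the first step really is, and compound 2 is recorded only as a limit, not as a number: the limit of > 10000 nM in this assay, at which 1 of the 4 values shown sits.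

The compounds shown leave open whether the outcome depends on the size of the group on the amide-type nitrogen or on its ester, since only 3-acetoxyphenyl and hydrogen appear there; a 3-hydroxyphenyl group, a plain phenyl group or a methyl group at that place on both cores could separate these possibilities. They also leave open how the change behaves on a third core, for example one carrying an amine or a carboxylic acid on its aryl ring.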